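The compounds below may be only part of what the source reports. "The series", "measured", "known", "first", "only" and "open" are said of these compounds alone.

Measured so far in a functional assay on BT-474 cells (Homo sapiens) for cytotoxicity, read by MTT assay, with a stated time of 48 h; a higher number here means a weaker inhibitor, a lower number a stronger inhibitor:
compound 1, `COc1ccc(N/C=C\C(=O)c2nc(-c3ccc(C(F)(F)F)cc3)n3ccccc23)cc1OC`: > 30000 nM
compound 2, `COc1ccc(N/C=C\C(=O)c2nc(-c3ccc(OC)cc3)n3ccccc23)cc1`: 15400 nM

Of the compounds shown here, two have been tested in this assay, and both are weak. For compound 1 the reading is only a limit of the assay, > 30000 nM, so compound 1 sits at the limit of > 30000 nM in this assay, at which 1 of the 2 values shown sits, and no number is known for it. Compound 2 gives 15400 nM in this assay. Compound 1 and compound 2 differ in two places, so their two values can only be set side by side, not read as a single step.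

Compound 3, `O=C(/C=C\Nc1ccc2[nH]ccc2c1)c1nc(-c2ccc(C(F)(F)F)cc2)n2ccccc12`, has not yet been measured. It differs from compound 1 in one place: 1H-indol-5-yl in place of 3,4-dimethoxyphenyl on an amine nitrogen. Going by the values given here, no measured pair shows the effect of such a change, and the one anchor, compound 1, sits at the limit of the assay. Compound 3 is therefore expected to stay weak, at an estimated 25000 nM, somewhere within 6000 nM to 80000 nM. The step from compound 1 to compound 3 is expected to be an at least 1.2-fold lower number from compound 1 to compound 3 (0.07 log units; that floor lies within the scatter), with the real chance that the assay again reports only a limit.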

Compound 3, half-maximal inhibitory concentration: 5190 nM
Compound 3: the middle estimate sits 4.8-fold (0.68 log units) above what was measured; measured number below the stated range.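

In this assay, putting 1H-indol-5-yl in place of 3,4-dimethoxyphenyl on the amine nitrogen, with the rest of the molecule unchanged, gives an at least 5.7-fold lower number from compound 1 to compound 3 (0.76 log units; beyond the scatter). Going by these compounds alone, this is the first direct sign that the group on this nitrogen can shift the reading, since compound 3, at 5190 nM, yields a real number where the earlier trifluoromethyl-bearing compound did not. The true size of the step remains unknown and only its lower bound can be read, because the reading for compound 1 is a limit of the assay and not a number: the limit of > 30000 nM in this assay, at which 1 of the 3 values shown sits.

The swap changes several things at once: two methoxy groups leave, while a five-membered aromatic ring and a hydrogen-bond donor enter, so this single pair cannot show which of these matters. Also open, from the compounds shown here alone, is whether a plain phenyl or a pyridine ring on the same nitrogen would give a similar reading, and whether 1H-indol-5-yl would lower the number in the same way on the background of compound 2.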